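This account rests on a few compounds, and the source may have more. Where it says the series, first, only, none or still open, it means among the compounds named here.

Measured compounds in a functional assay on HL-60 cells (Homo sapiens) for antiproliferative activity, read by MTT assay, with a stated time of 72 h; a lower number here means a stronger inhibitor, a higher number a weaker inhibitor:

compound 1 `NC1=NC2(CCOCC2)N(OCCCOc2ccccc2)C(N)=N1`: 2460 nM
compound 2 `Cc1cc(C)cc(OCCCON2C(N)=NC(N)=NC23CCOCC3)c1`: 720 nM
compound 3 `NC1=NC2(CCOCC2)N(OCCCOc2ccc(Cl)c(Cl)c2)C(N)=N1`: 1240 nM

Compound 1 has the highest number of the three in this assay. Its nearest neighbour is compound 3, reached by a 2.0-fold lower number from compound 1 to compound 3 (0.30 log units; within the scatter), a step that stays within the scatter. Its furthest is compound 2, reached by a 3.4-fold lower number from compound 1 to compound 2 (0.53 log units; beyond the scatter), a modest step beyond the scatter. Between compound 2 and compound 3 the step is a 1.7-fold higher number from compound 2 to compound 3 (0.24 log units; within the scatter), again within the scatter.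

Compound 4 `NC1=NC2(CCOCC2)N(OCCCOc2cccc(Cl)c2)C(N)=N1` differs from compound 1 as follows: chloro in place of hydrogen on an aromatic carbon. Within the data shown here, two measured steps bear on this change, both of which add substituents to the same phenyl ring of compound 1: a 3.4-fold lower number from compound 1 to compound 2 (0.53 log units; beyond the scatter) and a 2.0-fold lower number from compound 1 to compound 3 (0.30 log units; within the scatter). Both lower the number, one modestly, one within the scatter. A single chloro on the ring would be expected to behave like these, so a small lowering of the number is expected in this assay, of roughly a 1.6-fold lower number from compound 1 to compound 4 (0.21 log units; within the scatter). Compound 4 is therefore estimated at 1500 nM, with a range from 700 nM to 3500 nM.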

Compound 4, half-maximal inhibitory concentration: 520 nM
Compound 4: the middle estimate sits 2.9-fold (0.46 log units) above what was measured; measured number below the stated range.
By their numbers in this assay, from the lowest: compounds 4, 2, 3 and 1 (each within the scatter of the next, the first and the last beyond it).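

In this assay, a single chloro on the ring, giving the 3-chlorophenyl group, is enough to move the number beyond the scatter, with a 4.7-fold lower number from compound 1 to compound 4 (0.67 log units; beyond the scatter) as the step. The second chloro of the 3,4-dichlorophenyl group does not add to this, since taking it away gives a 2.4-fold lower number from compound 3 to compound 4 (0.38 log units; beyond the scatter) and so the monochloro ring is the better of the two. The 3-chlorophenyl group cannot be told apart from the 3,5-dimethylphenyl group, with a 1.4-fold lower number from compound 2 to compound 4 (0.14 log units; within the scatter) lying within the scatter.

Nothing given here accounts for these steps. Going by these compounds, whether a fluoro, a methoxy or a trifluoromethyl group at this place on the ring, or a longer chain to the phenoxy group, would hold the number at this level remains open.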